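The source may report more compounds than this note shows. Statements on the series, on what has been measured and on what is new or still open speak of the compounds shown alone.

Of the compounds shown here, two have been tested in an ADME assay on Huh-7 cells (Homo sapiens) for cytotoxicity, read by MTT assay, with a stated time of 48 h; on this read-out higher numbers stand for lower toxicity in this test and lower numbers for higher toxicity in this test. Compound 1, `CC(c1ccc(N(CCCCN(C)C)C(=O)O)cc1)n1nc(-c2ccc(F)cc2)c2ccccc2c1=O`, gives 15200 nM in this assay, and compound 2, `CN(C)CCCCOC(=O)Nc1ccc(Cn2nc(-c3cccnc3)c3ccccc3c2=O)cc1`, gives 68000 nM. Compound 2 therefore stands highest of the two numbers, with compound 1 sitting beyond the scatter below it. Compound 3, `CN(C)CCCCOC(=O)Nc1ccc(Cn2nc(-c3cccc(C#N)c3)c3ccccc3c2=O)cc1`, has not yet been measured. It differs from compound 2 in one place: 3-cyanophenyl in place of pyridin-3-yl on an aromatic carbon. The measured pair gives no guide to what this exchange does to toxicity, so the expected step is small, within the scatter: a 1.4-fold lower number from compound 2 to compound 3 (0.13 log units; within the scatter). Compound 3 is accordingly estimated at about 50000 nM in this assay, within a range from 20000 nM to 120000 nM.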

Compound 3, half-maximal cytotoxic concentration: 17200 nM
The estimate for compound 3 lay 2.9-fold (0.46 log units) above the measured number; the measured number lies below the stated range.
By their numbers in this assay, from the lowest: compounds 1 and 3 (each within the scatter of the next); then compound 2.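

The aromatic group at this position of the shared core matters: the step from pyridin-3-yl to 3-cyanophenyl gives a 4.0-fold lower number from compound 2 to compound 3 (0.60 log units; beyond the scatter) in this assay and lies beyond the usual scatter. Since lower numbers stand for higher toxicity in this test, compound 3 is the more toxic of this pair. Nothing available explains this step.

The exchange removes a ring nitrogen and adds a nitrile together, leaving open which of the two changes matters. A plain phenyl at this position would help separate them.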